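The compounds below may be only part of what the source reports. "The series", "measured", "known", "first", "only" and "open" are said of these compounds alone.

Of the compounds shown here, three built on one shared core have been tested in a functional assay on BCG823 cells (Homo sapiens) for inhibition, read by MTT assay, with a stated time of 72 h; a lower number here means a stronger inhibitor, a higher number a weaker inhibitor. Compound 1 `CN(C(=O)NC(=O)c1ccccc1F)c1nc(C(F)(F)F)c(C(=O)N/N=C/c2cc(C(F)(F)F)cc(C(F)(F)F)c2)s1` carries a 2-fluorophenyl on a carbonyl carbon, and in this assay compound 1 gives 4.23 ug/mL. Compound 2 `CN(C(=O)NC(=O)c1ccc(Cl)cc1Cl)c1nc(C(F)(F)F)c(C(=O)N/N=C/c2cc(C(F)(F)F)cc(C(F)(F)F)c2)s1` carries a 2,4-dichlorophenyl on that carbonyl carbon, and for compound 2 this assay reports only a limit, > 100 ug/mL. Compound 3 `CN(C(=O)NC(=O)c1cccc(C(F)(F)F)c1)c1nc(C(F)(F)F)c(C(=O)N/N=C/c2cc(C(F)(F)F)cc(C(F)(F)F)c2)s1` carries a 3-(trifluoromethyl)phenyl there, and compound 3 gives 5.23 ug/mL. Exchanging the ring gave an at least 23-fold higher number from compound 1 to compound 2 (1.37 log units; beyond the scatter), whereas a 1.2-fold higher number from compound 1 to compound 3 (0.09 log units; within the scatter). Compound 3 thus stands beside compound 1, separated from it only within the scatter, while the value of compound 2 sits at the limit (the limit of > 100 ug/mL in this assay, at which 1 of the 3 values shown sits).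

Compound 4 `CN(C(=O)NC(=O)c1ccc(C(F)(F)F)cc1)c1nc(C(F)(F)F)c(C(=O)N/N=C/c2cc(C(F)(F)F)cc(C(F)(F)F)c2)s1` is the next step: 4-(trifluoromethyl)phenyl in place of 3-(trifluoromethyl)phenyl on a carbonyl carbon. Among the measured compounds shown here, two measured steps bear on it. The first is an at least 19-fold lower number from compound 2 to compound 3 (1.28 log units; beyond the scatter), a large step in which the whole ring was swapped. The second is a 1.2-fold higher number from compound 1 to compound 3 (0.09 log units; within the scatter), a step that stayed within the scatter even though the ring changed entirely. Here the atoms are the same and only their arrangement differs, so the expected step of a 1.1-fold higher number from compound 3 to compound 4 (0.06 log units; within the scatter) is small, with no direction beyond the scatter. Compound 4 is expected to give about 6 ug/mL in this assay, estimated between 2 ug/mL and 30 ug/mL.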

Compound 4, half-maximal inhibitory concentration: 1.77 ug/mL
Estimate against measurement, compound 4: 3.4-fold (0.53 log units) above, outside the stated range (below it).
By their numbers in this assay, from the lowest: compound 4; then compounds 1 and 3 (each within the scatter of the next). At a limit, above all of these: compound 2.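

In this assay, among the compounds shown here, the same atoms joined differently on the carbonyl carbon give a 3.0-fold lower number from compound 3 to compound 4 (0.47 log units; beyond the scatter), so at this place the arrangement of the trifluoromethyl group on the phenyl ring counts, and not only which atoms are present, something the earlier compounds could not show because each of their rings differed in its atoms. The 4-(trifluoromethyl)phenyl ring also stands apart from the other two rings, with a 2.4-fold lower number from compound 1 to compound 4 (0.38 log units; beyond the scatter) and an at least 56-fold lower number from compound 2 to compound 4 (1.75 log units; beyond the scatter), and these steps, together with the first, make it the strongest inhibitor of the four shown. The value of compound 2 is only a limit: the limit of > 100 ug/mL in this assay, at which 1 of the 4 values shown sits.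

Going by these compounds, whether the gain belongs to the trifluoromethyl group itself or would also come with another group, such as a 4-chlorophenyl, a 4-methoxyphenyl or a 2-(trifluoromethyl)phenyl on that carbonyl carbon, stays open. On these data alone, whether the same order would hold on cells other than those of this assay stays open as well.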